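Methoxycarbonyl Added to a Bromobenzyl Thioether: An Expectation

The compounds below may be only part of what the source reports. "The series", "measured", "known", "first", "only" and "open" are said of these compounds alone.

Measured compounds in an assay on HEK293 cells for displacement of a labelled ligand from prostaglandin D2 receptor 2 (Homo sapiens); a lower number here means a stronger inhibitor, a higher number a weaker inhibitor:
compound 1, `CCCCCCSc1nc2ccccc2n1CC(=O)O`, gives 1360 nM
compound 2, `COc1ccc(CSc2nc3ccccc3n2CC(=O)O)cc1`, gives 210 nM
compound 3, `O=C(O)Cn1c(SCc2ccc(Br)cc2)nc2ccccc21`, gives 220 nM

Compound 3 holds the second highest of the three numbers. Its nearest neighbour is compound 2, and a 1.0-fold higher number from compound 2 to compound 3 (0.02 log units; within the scatter) lies within the scatter, so the two cannot be ordered. Its furthest is compound 1, and a 6.2-fold lower number from compound 1 to compound 3 (0.79 log units; beyond the scatter) is a clear, modest step.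

Compound 4, `COC(=O)c1cc(CSc2nc3ccccc3n2CC(=O)O)ccc1Br`, is not yet measured. Relative to compound 3 the change is methoxycarbonyl in place of hydrogen on an aromatic carbon.

Neither measured step bears directly on this change. The step from compound 1 to compound 3 swaps a pentyl for a 4-bromophenyl on the chain carbon bound to sulfur, and the step from compound 2 to compound 3 exchanges methoxy for bromo; both leave the ring position now being substituted untouched. Among the compounds with values here, the two aryl compounds sit close together, which suggests the ring tolerates change without large movement in this assay, but no compound shows what a methoxycarbonyl does there.

Compound 4 is therefore expected to stay near compound 3, with a 1.2-fold higher number from compound 3 to compound 4 (0.07 log units; within the scatter) at most a small shift, and an estimated 260 nM within 90 nM to 800 nM.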

Compound 4, half-maximal inhibitory concentration: 980 nM
Compound 4: middle estimate off by 3.8-fold (0.58 log units), on the low side, and the stated range ends below it.
By their numbers in this assay, from the lowest: compounds 2 and 3 (each within the scatter of the next); then compounds 4 and 1 (each within the scatter of the next).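

In this assay, the earlier aryl compounds had shown only that methoxy and bromo could be exchanged on the ring without a readable change, which said nothing about adding a group at a position that had carried only hydrogen. Compound 4 supplies that missing test, and a 4.5-fold higher number from compound 3 to compound 4 (0.65 log units; beyond the scatter) is a step beyond the scatter, seen when methoxycarbonyl enters on an aromatic carbon ortho to a bromo group and meta to a large group. The ring is therefore not indifferent to every change, and nothing available explains why this addition raises the number.

From the compounds shown here alone, it remains open whether the step belongs to methoxycarbonyl itself or would follow any added group at this place, and a methyl, a carboxylic acid or a primary amide on the same carbon would help separate those readings. Going by these compounds, it is equally open whether methoxycarbonyl would have the same effect with the bromo group replaced by methoxy, or at another carbon of the same ring.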